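Swapping a dimethylamino chain for a diol-bearing triazole

The source may report more compounds than this note shows. Statements on the series, on what has been measured and on what is new or still open speak of the compounds shown alone.

Measured so far:
- compound 1, `CC1(C)O[C@@H](CO)[C@H](Cn2cc(Cn3c4c(c5ccccc53)C(=O)c3c[n+]([O-])c5ccccc5c3C4=O)nn2)O1`: 370 nM
- compound 2, `CC1(C)OCC(Cn2cc(Cn3c4c(c5ccccc53)C(=O)c3c[n+]([O-])c5ccccc5c3C4=O)nn2)O1`: 80 nM
- compound 3, `CN(C)CCCCn1c2c(c3ccccc31)C(=O)c1c[n+]([O-])c3ccccc3c1C2=O`: 310 nM

All three share the same core and differ only in the group attached to the chain carbon bound to an aromatic nitrogen. In a functional assay on A549 cells (Homo sapiens) for cytotoxicity, read by MTT assay, with a stated time of 72 h (a lower number here means a stronger inhibitor, a higher number a weaker inhibitor), compound 3 stands second highest of the three numbers. Its nearest neighbour is compound 1, whose number lies within the usual scatter of it, so no order between compound 3 and compound 1 can be read. Compound 2 sits clearly lower, beyond the scatter.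

The new compound is compound 4, `O=C1c2c[n+]([O-])c3ccccc3c2C(=O)c2c1c1ccccc1n2Cc1cn(C[C@H](O)CO)nn1`. Relative to compound 3 it carries 1-(2,3-dihydroxypropyl)-1H-1,2,3-triazol-4-yl in place of 3-(dimethylamino)propyl on a saturated chain carbon bound to an aromatic nitrogen.

Within the data shown here, no measured step covers this particular exchange. Among the measured compounds shown here, the only step available, a 4.6-fold lower number from compound 1 to compound 2 (0.67 log units; beyond the scatter), shows that within the triazole series the smaller 2,2-dimethyl-1,3-dioxolan-4-yl gave a modestly lower number than the 5-(hydroxymethyl)-2,2-dimethyl-1,3-dioxolan-4-yl. Compound 4 carries a 2,3-dihydroxypropyl on its triazole, closer in kind to the hydroxymethyl-bearing compound 1 than to compound 2. Compound 4 is therefore expected to land near compound 1, with a 1.6-fold higher number from compound 3 to compound 4 (0.21 log units; within the scatter), and its estimated value is 500 nM, within a range from 150 nM to 1600 nM.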

Compound 4, half-maximal inhibitory concentration: 1030 nM
Compound 4: the middle estimate sits 2.1-fold (0.31 log units) below what was measured; the range from low to high includes it.
By their numbers in this assay, from the lowest: compound 2; then compounds 3 and 1 (each within the scatter of the next); then compound 4.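

In this assay compound 4 is the weakest of the four, as every step to it lies beyond the scatter. The exchange of the 3-(dimethylamino)propyl chain for the triazole with its open diol gives a 3.3-fold higher number from compound 3 to compound 4 (0.52 log units; beyond the scatter) at this position, so in this comparison the new group does not match the amine chain. The two triazole compounds with the closed dioxolane ring both give lower numbers, with a 2.8-fold higher number from compound 1 to compound 4 (0.44 log units; beyond the scatter) from the one with a hydroxymethyl group and a 13-fold higher number from compound 2 to compound 4 (1.11 log units; beyond the scatter) from the one without it, so among these triazoles the free 1,2-dihydroxyethyl group goes with the highest number.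

No measurement shown explains why the open diol gives the higher number. From the compounds shown here alone, because the step from compound 3 to compound 4 changes both the triazole and the chain end together, the share of each stays open, and a triazole carrying a dimethylamino group or a plain butyl chain on the same position would be needed to separate the two.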